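The source may hold more compounds than are shown below. What is called first, only, known or untested is meant among the compounds shown, and "the series" means these compounds.

Of the compounds shown here, three have been tested so far in a functional assay on 4T1 cells (Mus musculus) for cytotoxicity, read by MTT assay, with a stated time of 24 h; a higher number here means a weaker inhibitor, a lower number a stronger inhibitor. Compound 1 `Cc1ccc(/C=C2\CN(C(=S)SCc3cn(Cc4cccc(Cl)c4)nn3)C/C(=C\c3ccc(C)cc3)C2=O)cc1` gives 53400 nM. Compound 2 `O=C1/C(=C/c2ccccc2F)CN(C(=S)SCc2cn(Cc3ccccc3F)nn2)C/C1=C\c1ccccc1F` gives 30700 nM, which lies within the scatter of compound 1, so the two cannot be told apart. Compound 3 `Cc1ccc(/C=C2\CN(Cc3cn(Cc4ccccc4Cl)nn3)C/C(=C\c3ccc(C)cc3)C2=O)cc1` gives 23200 nM, a lower number than compound 1 by more than the scatter. Compound 1 therefore stands at the weak end of this small set, level with compound 2.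

The next compound to be measured is compound 4 `Cc1ccc(/C=C2\CN(C(=S)SCc3cn(Cc4ccccc4Cl)nn3)C/C(=C\c3ccc(C)cc3)C2=O)cc1`. It differs from compound 1 by one swap, 2-chlorophenyl in place of 3-chlorophenyl on a saturated chain carbon bound to an aromatic nitrogen. Among the compounds with values here, no measured pair shows this change on its own, so there is no direct guide to its effect. All the measured numbers sit close together, from compound 3 at 23200 nM to compound 1 at 53400 nM, so no step beyond the scatter is expected in this assay. The expected result is a 1.3-fold lower number from compound 1 to compound 4 (0.13 log units; within the scatter), a slightly lower number. For compound 4 the estimated value is 40000 nM, with an expected range from 20000 nM to 80000 nM.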

Compound 4, half-maximal inhibitory concentration: 49300 nM
Compound 4: middle estimate off by 1.2-fold (0.09 log units), on the low side; low and high end bracket the measured number.
By their numbers in this assay, from the lowest: compounds 3, 2, 4 and 1 (each within the scatter of the next, the first and the last beyond it).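

Swapping 3-chlorophenyl for 2-chlorophenyl on a saturated chain carbon bound to an aromatic nitrogen gives a 1.1-fold lower number from compound 1 to compound 4 (0.03 log units; within the scatter) in this assay. Within the data shown here, this is the first direct reading of this position with the rest of the molecule held fixed, and it shows that this swap of chlorophenyl groups leaves no measurable mark on the number, though a single pair cannot speak for other groups at this place. No measurement on hand offers an explanation for this result.

From the compounds shown here alone, what remains open is whether a different kind of group at this place would move the number beyond the scatter, such as a plain benzyl, a benzyl ring carrying an amine or a carboxylic acid, or a longer chain. The compounds shown also leave open whether the same swap would behave alike on a different version of the shared core.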